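The compounds below may be only part of what the source reports. "The series", "measured", "known", "first", "only" and "open" are said of these compounds alone.

Measured so far:

compound 1 — `N#Cc1ccc(Oc2cnccc2SCCCCC(=O)O)c2ccccc12` — 4220 nM
compound 2 — `CN(c1cnccc1SCCCCC(=O)O)c1ccc(C#N)c2ccccc12` — 3580 nM

Both compounds were tested in an assay on HEK293 cells for inhibition of solute carrier family 22 member 12 (Homo sapiens), read by scintillation counting, with stated times of 30 min and 15 min; a lower number here means a stronger inhibitor, a higher number a weaker inhibitor. Compound 1 gives 4220 nM in this assay, and compound 2 gives 3580 nM. Compound 2 has the lowest of the two numbers, but its gap to compound 1 is within the usual scatter of repeated measurements, so the two cannot be told apart.

The next compound, compound 3, has the structure `CN(c1cnccc1SCCCCCC(=O)O)c1ccc(C#N)c2ccccc12`. It differs from compound 2 in one place: carboxymethyl in place of carboxy on a saturated chain carbon, four bonds along the chain from a sulfur. The acid chain is thus extended by one carbon while everything else stays the same. Among the compounds with values here, no pair of measured compounds shows such a chain extension, so there is no measured step to lean on. The expected change from compound 2 to compound 3 is therefore small, a 1.1-fold lower number from compound 2 to compound 3 (0.05 log units; within the scatter), in no particular direction and not beyond the scatter. Compound 3 is estimated at 3200 nM, with a range from 1200 nM to 8500 nM.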

Compound 3, half-maximal inhibitory concentration: 3760 nM
Compound 3: the middle estimate sits 1.2-fold (0.07 log units) below what was measured, within the range that was stated.
By their numbers in this assay, from the lowest: compounds 2, 3 and 1 (each within the scatter of the next).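

Replacing carboxy with carboxymethyl on a saturated chain carbon, four bonds along the chain from a sulfur, gives a 1.1-fold higher number from compound 2 to compound 3 (0.02 log units; within the scatter) in this assay, so the two compounds cannot be told apart. Within the data shown here, this is the first measured change to the acid chain, and it shows that, for this one pair, adding one carbon leaves no measurable mark on the number. No outside measurement bears on this result.

The compounds shown leave open whether a longer chain, with 2-carboxyethyl or 3-carboxypropyl in the same place, or a shorter chain would also leave the number within the scatter. They also leave open what would happen if an amide or a tetrazole took the place of the carboxylic acid at the end of the chain.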